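Benzamide series: aryl versus benzyl amine at the core

The source may report more compounds than this note shows. Statements on the series, on what has been measured and on what is new or still open speak of the compounds shown alone.

Three compounds carry the shared core. Compound 1 `Nc1ccccc1NC(=O)/C=C/c1ccc(Cn2cnc3c(Nc4cccc(Cl)c4)nc(Cl)nc32)cc1` gives 49.3% in a functional assay on HepG2 cells (Homo sapiens) for antiproliferative activity, read by CCK-8 assay, with a stated time of 72 h, tested at 8 uM; on this read-out higher numbers stand for a stronger effect at the one concentration tested and lower numbers for a weaker effect; compound 2 `Nc1ccccc1NC(=O)c1ccc(Cn2cnc3c(Nc4ccccc4)nc(Cl)nc32)cc1` gives 74.8%; compound 3 `Nc1ccccc1NC(=O)c1ccc(Cn2cnc3c(NCc4ccccc4)nc(Cl)nc32)cc1` gives 62.8%, the second highest of the three, between compound 2 and compound 1. Going by the values given here, the one single-site step measured, a number 12 percentage points lower from compound 2 to compound 3 (beyond the scatter), went with benzyl replacing phenyl. Compound 4 `Nc1ccccc1NC(=O)c1ccc(Cn2cnc3c(Nc4cccc(Cl)c4)nc(Cl)nc32)cc1` is the unmeasured analogue; the change from compound 3 is 3-chlorophenyl in place of benzyl on a nitrogen on an aromatic ring. Among the compounds with values here, it returns an aryl group to that nitrogen, the reverse of the measured step, with an added chlorine for which no matched pair exists; compound 1 holds the same 3-chlorophenyl on a different linker and gives a lower number, but that pair is not a single-site step. The estimate for compound 4 is therefore 70%, expected range 52% to 84%, an expected rise of a number 7.2 percentage points higher from compound 3 to compound 4 (within the scatter), roughly undoing the drop seen from compound 2 to compound 3.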

Compound 4, a percentage reported as inhibition, at one concentration (the size of the read-out at that concentration, not a potency): 66.7%
Compound 4: the middle estimate sits 3.3 percentage points above what was measured; low and high end bracket the measured number.
By their numbers in this assay, from the lowest: compound 1; then compounds 3, 4 and 2 (each within the scatter of the next, the first and the last beyond it).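

At this nitrogen, 3-chlorophenyl in place of benzyl gives a number 3.9 percentage points higher from compound 3 to compound 4 (within the scatter) and so does not establish a gain over benzyl. Chloro in place of hydrogen on an aromatic carbon gives a number 8.1 percentage points lower from compound 2 to compound 4 (within the scatter) and so cannot be told apart from no change. Going by these compounds alone, the one step here beyond the scatter is a number 17.4 percentage points higher from compound 1 to compound 4 (beyond the scatter) with (2-aminophenyl)carbamoyl in place of 2-((2-aminophenyl)carbamoyl)ethenyl on an aromatic carbon.

As far as these compounds go, whether a methoxy group or a carboxylic acid in place of the chloro would hold the number remains open. No available evidence explains any of these steps.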